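This account rests on a few compounds, and the source may have more. Where it says the series, first, only, none or still open, it means among the compounds named here.

In an assay on CHO cells for displacement of a labelled ligand from adenosine receptor A3 (Homo sapiens), read by scintillation counting, with a stated time of 120 min, tested at 10 uM (a lower number here means less inhibition, a higher number more inhibition at the concentration tested (going by the name of the read-out)), compound 3 `Nc1scc(CN2CCN(c3ccc(OC(F)(F)F)cc3)CC2)c1C(=O)c1ccc(Cl)cc1` gives 1%. Among the three numbers shown, compound 3 stands second highest, although every step between it and the others lies within the scatter. Compound 1 `CC(C)N1CCN(Cc2csc(N)c2C(=O)c2ccc(Cl)cc2)CC1` gives 0%, and compound 2 `Nc1scc(CN2CCN(c3ccc(Cl)c(C(F)(F)F)c3)CC2)c1C(=O)c1ccc(Cl)cc1` gives 3%. Compound 4 `Nc1scc(CN2CCN(c3ccccc3F)CC2)c1C(=O)c1ccc(Cl)cc1` has not yet been measured. The change from compound 3 to compound 4 is 2-fluorophenyl in place of 4-(trifluoromethoxy)phenyl on an amine nitrogen in a ring. For the measured compounds named here, two measured steps touch the same place, the amine nitrogen in the ring: a number 1 percentage points higher from compound 1 to compound 3 (within the scatter) and a number 2 percentage points lower from compound 2 to compound 3 (within the scatter). Neither step moves the read-out beyond the scatter, whether an isopropyl or a substituted phenyl sits on that nitrogen. Replacing one substituted phenyl with another at the same place is therefore expected to give no step beyond the scatter in either direction. The expected step is no change at the digits printed from compound 3 to compound 4 (within the scatter). Compound 4 is thus estimated to give 1% in this assay, with a range from -8% to 10%.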

Compound 4, a percentage reported as inhibition, at one concentration (the size of the read-out at that concentration, not a potency): 0%
The estimate for compound 4 lay 1 percentage points above the measured number; measured number inside the range.
By their numbers in this assay, from the lowest: compounds 1, 4, 3 and 2 (each within the scatter of the next).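

In this assay, the new group gives a number 1 percentage points lower from compound 3 to compound 4 (within the scatter), along with a number 3 percentage points lower from compound 2 to compound 4 (within the scatter) and no change at the digits printed from compound 1 to compound 4 (within the scatter). For the compounds shown here, the flat picture at this amine nitrogen in a ring therefore extends to 2-fluorophenyl, which has 7 heavy atoms and no hydrogen-bond acceptor, whereas 4-(trifluoromethoxy)phenyl has 11 heavy atoms and one acceptor; across isopropyl and the three substituted phenyl groups, no step goes beyond the scatter. Nothing available explains this lack of response.

The compounds shown leave open whether a group of a different kind on this nitrogen, such as a carboxylic acid or a longer chain ending in an amine, would move the read-out beyond the scatter. On these data alone, what a change elsewhere on the shared core would do also remains open.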